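This account rests on a few compounds, and the source may have more. Where it says the series, first, only, none or still open, it means among the compounds named here.

In an ADME assay on MCF7-DOX cells (Homo sapiens) for cytotoxicity, read by MTT assay, with a stated time of 48 h (a lower number here means a stronger inhibitor, a higher number a weaker inhibitor), compound 1 (`COc1cc(OC)c(C(=O)/C=C/c2cccc(F)c2)c(O)c1CC=C(C)C`) gives 45400 nM, compound 2 (`COc1cc(OC)c(C(=O)/C=C/c2cccc([N+](=O)[O-])c2)c(O)c1CC=C(C)C`) gives 57000 nM, and compound 3 (`COc1cc(OC)c(C(=O)/C=C/c2cccc(N3CCN(C(=O)OC(C)(C)C)CC3)c2)c(O)c1CC=C(C)C`) gives 42600 nM, so all three values lie within the scatter of one another. Compound 4 (`COc1cc(OC)c(C(=O)/C=C/c2cccc(N3CCN(C)CC3)c2)c(O)c1CC=C(C)C`) differs from compound 3 in one place: methyl in place of tert-butoxycarbonyl on an amine nitrogen in a ring, which is methyl in place of tert-butoxycarbonyl on an amine nitrogen in a ring. Within the data shown here, the only measured step, a 1.3-fold higher number from compound 1 to compound 2 (0.10 log units; within the scatter), is a different exchange, nitro in place of fluoro on an aromatic carbon, so it offers only indirect guidance. Among the measured compounds shown here, no measured step tests the new exchange, so no change beyond the scatter is expected in this assay, and the range stays wide. The expected step is a 1.2-fold lower number from compound 3 to compound 4 (0.07 log units; within the scatter). Compound 4 is estimated at 36000 nM, with an expected range of 15000 nM to 70000 nM.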

Compound 4, half-maximal inhibitory concentration: > 100000 nM
Compound 4: no number, only a limit (the forecaster's own chance of this, stated with the estimate: 5%); at least 2.7-fold (0.44 log units) between middle value and limit.
By their numbers in this assay, from the lowest: compounds 3, 1 and 2 (each within the scatter of the next). At a limit, above all of these: compound 4.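

In this assay, the group on the amine nitrogen in a ring is the first change shown to move the number beyond the scatter: methyl in place of tert-butoxycarbonyl gives an at least 2.3-fold higher number from compound 3 to compound 4 (0.37 log units; beyond the scatter). The 4-methylpiperazin-1-yl group gives an at least 2.2-fold higher number from compound 1 to compound 4 (0.34 log units; beyond the scatter) in place of fluoro, and an at least 1.7-fold higher number from compound 2 to compound 4 (0.24 log units; that floor lies within the scatter) in place of nitro. Going by these compounds, compound 4 reaches only a limit of the assay, so these steps are floors and their full sizes stay unknown.

On these data alone, whether a plain hydrogen, an acetyl group or a longer chain on that nitrogen would stay close to compound 3 or compound 4 remains open.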